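The source may hold more compounds than are shown below. What is called first, only, known or untested is meant among the compounds shown, and "the series" means these compounds.

Measured compounds:
compound 1 `O=C(O)Cc1sc(C(c2ccc(F)cc2)c2ccc(F)cc2)nc1-c1ccnc(F)c1`, an in vitro functional assay on HEK285-7 cells for antagonist activity at prostaglandin D2 receptor 2 (Homo sapiens), read by BRET and beta-arrestin recruitment; on this read-out lower numbers stand for smaller maximal responses and higher numbers for larger maximal responses: 80%
compound 2 `O=C(O)Cc1sc(C(c2ccccc2)c2ccccc2)nc1-c1ccc(C(F)(F)F)cc1`, this assay: 80%

Compound 1 stands level with compound 2 in this assay; the two values lie within the scatter of each other, so no order can be read from them. Compound 3 `CN(C)c1cc(-c2nc(C(c3ccc(F)cc3)c3ccc(F)cc3)sc2CC(=O)O)ccn1` is not yet measured. It differs from compound 1 by dimethylamino in place of fluoro on an aromatic carbon. Within the data shown here, no measured pair carries this kind of change, so the expectation rests on the value of compound 1 alone. The expected step in this assay is a number 5 percentage points lower from compound 1 to compound 3 (within the scatter), small and not clearly beyond the scatter in either direction. For compound 3 the expected value in this assay is 75%, with a range from 55% to 95%.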

Compound 3, largest response reached (reported as efficacy), in percent of the reference or control that the assay uses: 80%
Compound 3: middle estimate off by 5 percentage points, on the low side; measured number inside the range.
By their numbers in this assay, from the lowest: compounds 1, 2 and 3 (each within the scatter of the next).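

In this assay, the exchange of 2-fluoropyridin-4-yl for 2-(dimethylamino)pyridin-4-yl gives no change at the digits printed from compound 1 to compound 3 (within the scatter) on the shared core. Among these compounds, this carbon next to the ring nitrogen therefore accepts dimethylamino in place of fluoro with no readable shift in maximal response, which the earlier compounds could not show. No measurement here accounts for this outcome.

Open, on these data alone, is whether a smaller primary amine, a methoxy group or a morpholine ring at this carbon would also leave the response in place. Also open, as far as these compounds go, is whether dimethylamino behaves alike at other ring positions.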